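The source may report more compounds than this note shows. Statements on the series, on what has been measured and on what is new or still open speak of the compounds shown alone.

Compound 2 `Cc1cccc(F)c1-c1nc(CN2CCC(C(=O)NCCCN3C[C@H](C)C[C@H](C)C3)CC2)c(C)o1` gives the highest of the two numbers recorded in an ADME assay on Huh7.5.1 cells (Homo sapiens) for cytotoxicity, read by ATP content, with a stated time of 48 h; a lower number here means that less compound is tolerated, a higher number that more compound is tolerated: compound 2 gives 13000 nM, while compound 1 `Cc1ccc(C)c(-c2nc(CN3CCC(C(=O)NCCCN4C[C@H](C)C[C@H](C)C4)CC3)c(C)o2)c1` gives 4070 nM. Among the measured compounds shown here, the one measured step, a 3.2-fold higher number from compound 1 to compound 2 (0.50 log units; beyond the scatter), replaced 2,5-dimethylphenyl with 2-fluoro-6-methylphenyl. Compound 3 `COc1cccc(F)c1-c1nc(CN2CCC(C(=O)NCCCN3C[C@H](C)C[C@H](C)C3)CC2)c(C)o1` is not yet measured; it differs from compound 2 by methoxy in place of methyl on an aromatic carbon, so the aryl group reads 2-fluoro-6-methoxyphenyl instead of 2-fluoro-6-methylphenyl. For the measured compounds named here, the measured step concerned a different exchange on the same ring and bears only loosely on this one; no measured pair shows methoxy in place of methyl. The step is therefore expected to stay within the scatter, as no change at the digits printed from compound 2 to compound 3 (within the scatter). Compound 3 is estimated to give 13000 nM in this assay, with a range from 5000 nM to 35000 nM.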

Compound 3, half-maximal cytotoxic concentration: 37000 nM
Beside the measured number, compound 3's estimate is 2.8-fold (0.45 log units) below it; the whole stated range lies below it.
By their numbers in this assay, from the lowest: compound 1; then compound 2; then compound 3.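

Methoxy in place of methyl on this aromatic carbon gives a 2.8-fold higher number from compound 2 to compound 3 (0.45 log units; beyond the scatter) in this assay, the first measured sign that this one group, with the fluoro group kept, can move the number beyond the scatter. The wider exchange, 2-fluoro-6-methoxyphenyl in place of 2,5-dimethylphenyl, gives a 9.1-fold higher number from compound 1 to compound 3 (0.96 log units; beyond the scatter), so more compound is tolerated with this aryl group than with either of the other two. Nothing available explains this rise.

The compounds shown leave open whether an ethoxy group, a hydroxyl group or a dimethylamino group on the same carbon would give a higher or lower number than methoxy. They also leave open whether chloro in place of the fluoro group would keep the number of compound 3.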